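One More Ring Swap, Little Change Expected

The source may hold more compounds than are shown below. What is called first, only, known or untested is meant among the compounds shown, and "the series" means these compounds.

In a functional assay on PC-3 cells (Homo sapiens) for cytotoxicity, read by MTT assay, with a stated time of 72 h (a higher number here means a weaker inhibitor, a lower number a stronger inhibitor), compound 1 `O=C(N/N=C/c1ccc(F)cc1Cl)Nc1cc2c(Nc3ccc(F)c(Cl)c3)ncnc2cc1O[C@H]1CCOC1` gives 28400 nM and compound 2 `COc1ccc(/C=N/NC(=O)Nc2cc3c(Nc4ccc(F)c(Cl)c4)ncnc3cc2O[C@H]2CCOC2)c(OC)c1OC` gives 25600 nM. Compound 2 therefore stands level with compound 1, as the two values lie within the usual scatter of repeated measurements. Compound 3 `O=C(N/N=C/c1ccc(O)c(Br)c1)Nc1cc2c(Nc3ccc(F)c(Cl)c3)ncnc2cc1O[C@H]1CCOC1` differs from compound 2 at a single place: 3-bromo-4-hydroxyphenyl in place of 2,3,4-trimethoxyphenyl on a carbon with a double bond to nitrogen. For the measured compounds named here, only one measured step bears on this swap: a 1.1-fold lower number from compound 1 to compound 2 (0.05 log units; within the scatter), made at the same place and within the scatter. Going by the values given here, no step beyond the scatter is therefore expected in this assay, although no measured compound carries 3-bromo-4-hydroxyphenyl, so the range stays wide. The expected change is a 1.3-fold lower number from compound 2 to compound 3 (0.11 log units; within the scatter). The estimate for compound 3 is 20000 nM, with an expected range of 8000 nM to 45000 nM.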

Compound 3, half-maximal inhibitory concentration: 5230 nM
Compound 3: the middle estimate sits 3.8-fold (0.58 log units) above what was measured; measured number outside the range, below it.
By their numbers in this assay, from the lowest: compound 3; then compounds 2 and 1 (each within the scatter of the next).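

In this assay the group on the carbon with a double bond to nitrogen proves able to shift the number beyond the scatter: 3-bromo-4-hydroxyphenyl brings a 4.9-fold lower number from compound 2 to compound 3 (0.69 log units; beyond the scatter) and a 5.4-fold lower number from compound 1 to compound 3 (0.73 log units; beyond the scatter) while the earlier swap at this place stayed within it. So this place is not indifferent to change, and the entering group differs from 2,3,4-trimethoxyphenyl in having fewer heavy atoms, a bromine and a hydrogen-bond donor, all arriving in one swap. Nothing measured here explains why this group lowers the number.

The compounds shown leave open whether the step belongs to the hydroxy group, the bromine or the two together. They also leave open how a phenyl ring carrying an amine or a carboxylic acid would behave at this place.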